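The source may hold more compounds than are shown below. What is called first, only, known or untested is meant among the compounds shown, and "the series" means these compounds.

Measured so far:

- compound 2, `Cc1ccc(C2SCC(=O)N2CCN2CCCCC2)cc1`: 100%
- compound 1, `O=C1CSC(c2c(Cl)cccc2Cl)N1CCN1CCCCC1`: 76%

In an ADME assay on Vero cells (Chlorocebus sabaeus) for cytotoxicity, read by neutral red uptake, tested at 98 ug/mL (on this read-out higher numbers stand for a weaker effect at the one concentration tested and lower numbers for a stronger effect), compound 2 gives 100%, the highest of the two numbers at hand. Its nearest neighbour is compound 1, which in this assay gives 76%, a number lower by a gap beyond the scatter. Among the compounds with values here, no pair of measured compounds differs in a single place, so no step of known size is available for this series.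

The next compound is compound 3, `O=C1CSC(c2ccccc2Cl)N1CCN1CCCCC1`. It differs from compound 2 as follows: 2-chlorophenyl in place of 4-methylphenyl on a saturated ring carbon. With only the two values of compound 1 and compound 2 to go on, a step downward from compound 2 is expected, of modest size, near the edge of the scatter: a number 12 percentage points lower from compound 2 to compound 3 (beyond the scatter). For compound 3 the estimate in this assay is 88%, with a range from 70% to 100%.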

Compound 3, a percentage reported as activity, at one concentration (the size of the read-out at that concentration, not a potency): 94%
The estimate for compound 3 lay 6 percentage points below the measured number; measured number inside the range.
By their numbers in this assay, from the lowest: compound 1; then compounds 3 and 2 (each within the scatter of the next).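

In this assay, 2-chlorophenyl in place of 4-methylphenyl on a saturated ring carbon gives a number 6 percentage points lower from compound 2 to compound 3 (within the scatter), so this exchange does not separate the two compounds on this read-out. Hydrogen in place of chloro on an aromatic carbon gives a number 18 percentage points higher from compound 1 to compound 3 (beyond the scatter), the first step in the series beyond the scatter, and it places the gap between compound 1 and compound 3 at that single aromatic carbon. No measurement at hand accounts for either step.

Within the data shown here, with only this one chloro step, it remains open whether the same exchange would give a similar step on another aromatic carbon or in another aryl group. Also open, as far as these compounds go, is how a nitrile, a methoxy group or a carboxylic acid on the phenyl ring would read in this assay.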